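Swapping the Five-Membered Ring on a Desaturase Inhibitor

The compounds below may be only part of what the source reports. "The series", "measured", "known", "first", "only" and "open" are said of these compounds alone.

Compound 1 `Oc1nnc(-c2ccc(N3CCC(Oc4ccccc4C(F)(F)F)CC3)nn2)s1`: 6.1 nM
Compound 2 `FC(F)(F)c1ccccc1OC1CCN(c2ccc(-c3nnco3)nn2)CC1`: 22 nM

Two compounds share a core and differ only in the five-membered ring attached to it. In an assay on microsomes from liver for inhibition of acyl-CoA desaturase 1 (Rattus norvegicus) (on this read-out higher numbers stand for weaker inhibition and lower numbers for stronger inhibition), compound 1 gives 6.1 nM, and compound 2 gives 22 nM. Within the data shown here, compound 2 therefore holds the higher of the two numbers, its only neighbour being compound 1, separated by a 3.6-fold higher number from compound 1 to compound 2 (0.56 log units; beyond the scatter).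

Compound 3 `Cc1nnc(-c2ccc(N3CCC(Oc4ccccc4C(F)(F)F)CC3)nn2)s1` has not yet been measured. Its change from compound 2 is 5-methyl-1,3,4-thiadiazol-2-yl in place of 1,3,4-oxadiazol-2-yl on an aromatic carbon. This change brings back the thiadiazole ring type seen in compound 1, but with a methyl group where compound 1 carries a hydroxyl. Among the measured compounds shown here, the only step that bears on it is a 3.6-fold higher number from compound 1 to compound 2 (0.56 log units; beyond the scatter), which went from a thiadiazole to the oxadiazole and raised the number modestly. Reversing that ring type would be expected to pull the number back down, while the methyl in place of the hydroxyl has no measured precedent here, so the expected step is tempered. Relative to compound 2, compound 3 is therefore expected to show a 2.4-fold lower number from compound 2 to compound 3 (0.39 log units; beyond the scatter). Compound 3 is estimated at 9 nM, with a range from 3 nM to 27 nM.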

Compound 3, half-maximal inhibitory concentration: 2.3 nM
Estimate against measurement, compound 3: 3.9-fold (0.59 log units) above; measured number outside the range, below it.
By their numbers in this assay, from the lowest: compound 3; then compound 1; then compound 2.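

In this assay, the move from the 1,3,4-oxadiazol-2-yl ring to the 5-methyl-1,3,4-thiadiazol-2-yl ring gives a 9.6-fold lower number from compound 2 to compound 3 (0.98 log units; beyond the scatter), which is a larger step than the earlier one between compound 1 and compound 2, and in the opposite direction. Within the thiadiazole series, the hydroxy group is not needed to keep the number low: putting methyl in its place gives a 2.7-fold lower number from compound 1 to compound 3 (0.42 log units; beyond the scatter), so this spot on the five-membered ring accepts either substituent, and methyl gives the lower number of the two. No measurement here explains why either change moves the number as it does.

On these data alone, the step from compound 2 to compound 3 changes the ring and adds the methyl at the same time, so the share of each remains open, and a 5-methyl-1,3,4-oxadiazol-2-yl group would help to separate them. How an ethyl group or an amine would compare with the methyl on the thiadiazole ring also remains an open question.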